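Heteroaromatic Ring Replaces Cyclopentyl on the Carbonyl Carbon

This account rests on a few compounds, and the source may have more. Where it says the series, first, only, none or still open, it means among the compounds named here.

Within the data shown here, compound 2 `Cc1nc(S(C)(=O)=O)ccc1Oc1ncnc(OC2CCN(C(=O)C3CCCC3)CC2)c1F` stands at the top of the two numbers measured so far in a functional assay on isolated protein for inhibition of Glucose-dependent insulinotropic receptor (Rattus norvegicus), read by HTRF and cAMP accumulation (a higher number here means a larger maximal response, a lower number a smaller maximal response), where compound 2 gives 83%. Its nearest neighbour, compound 1 `Cc1nc(S(C)(=O)=O)ccc1Oc1ncnc(OC2CCN(C(=O)SC3CCC3)CC2)c1F`, gives 81% in this assay, and the step of a number 2 percentage points higher from compound 1 to compound 2 (within the scatter) lies within the scatter, so the two cannot be placed in any order.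

Compound 3 `Cc1nc(S(C)(=O)=O)ccc1Oc1ncnc(OC2CCN(C(=O)c3nc(C(C)(C)F)no3)CC2)c1F` differs from compound 2 by a group of 9 heavy atoms (5 carbon, 2 nitrogen, 1 oxygen, 1 fluorine; one five-membered aromatic ring with 3 hetero atoms) in place of a group of 5 heavy atoms (5 carbon; one five-membered non-aromatic ring of carbon only), on a carbonyl carbon.

Among the measured compounds shown here, only one measured step bears on this change, and it concerns a different replacement at the same carbonyl carbon, cyclopentyl for cyclobutylsulfanyl: it was a number 2 percentage points higher from compound 1 to compound 2 (within the scatter), within the scatter. For the measured compounds named here, no measured step brings an aromatic ring with hetero atoms to this position, so the data offer no direct guide for the entering group. Since the two measured compounds sit close together, the expected step of a number 3 percentage points lower from compound 2 to compound 3 (within the scatter) is none beyond the scatter, though the range is kept wide for the untested group. For compound 3 the estimated value in this assay is 80%, with a range from 62% to 96%.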

Compound 3, largest response reached (reported as efficacy), in percent of the reference or control that the assay uses: 84%
Beside the measured number, compound 3's estimate is 4 percentage points below it, within the range that was stated.
By their numbers in this assay, from the lowest: compounds 1, 2 and 3 (each within the scatter of the next).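

In this assay the carbonyl carbon bound to the amide-type nitrogen in a ring accepts a five-membered aromatic ring with 3 hetero atoms, a group with hydrogen-bond acceptors where cyclopentyl has none, and the change gives a number 1 percentage points higher from compound 2 to compound 3 (within the scatter). Set against the cyclobutylsulfanyl group, the same entering group gives a number 3 percentage points higher from compound 1 to compound 3 (within the scatter), so the maximal response does not separate an aromatic ring with hetero atoms from either non-aromatic carbon ring, whether that ring is attached directly or through sulfur. No measurement at hand accounts for this result.

Among these compounds, every step at this place so far lies within the scatter, so it remains unknown whether any group on this carbonyl carbon, such as a primary amine, a carboxylic acid or a longer alkyl chain, would move the maximal response beyond it. From the compounds shown here alone, it is also open whether the same aromatic ring without its fluorine, or with a different group in place of that fluorine-bearing carbon, would keep the response seen for compound 3 .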